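A few compounds are considered here, and "the series" means these few. Any claim that something is new, unique, unknown or untested is made for them only; others in the source may bear on it.

Measured compounds:
- compound 1 `N/C(CC(O)c1ccc2ccccc2c1)=N\N=C\c1cccnc1` — in an ADME assay on L6 cells (Rattus norvegicus) for cytotoxicity, read by resazurin assay, with a stated time of 72 h (on this read-out higher numbers stand for weaker inhibition and lower numbers for stronger inhibition), compound 1 gives "not determined" (no result reported)
- compound 2 `N/C(CC(O)c1cccc2ccccc12)=N\N=C\c1ccc(Cl)c(Cl)c1` — 16000 nM

Among the compounds with values here, compound 2 holds the only number so far; for compound 1 no value was reported, so nothing can be set beside compound 2. Compound 3 `N/C(CC(O)c1cccc2ccccc12)=N\N=C\c1cccc(Br)c1` has not been measured. It differs from compound 2 in one place: 3-bromophenyl in place of 3,4-dichlorophenyl on a carbon with a double bond to nitrogen. Within the data shown here, with no step between measured compounds to lean on, the change is expected to stay within the scatter, a 1.3-fold higher number from compound 2 to compound 3 (0.10 log units; within the scatter), with no clear direction. Compound 3 is therefore estimated at 20000 nM, within a range of 8000 nM to 50000 nM.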

Compound 3, half-maximal inhibitory concentration: 3900 nM
Estimate against measurement, compound 3: 5.1-fold (0.71 log units) above, and the stated range ends above it.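

In this assay, this position on a carbon with a double bond to nitrogen responds to the group it carries: 3-bromophenyl in place of 3,4-dichlorophenyl gives a 4.1-fold lower number from compound 2 to compound 3 (0.61 log units; beyond the scatter) and so moves toward stronger inhibition. Within the data shown here, this is the first measured step, and it shows that a change to this group alone can exceed the usual scatter. No measured evidence here explains the change.

The change swaps two chlorines for one bromine, so the step cannot be assigned to either atom. From the compounds shown here alone, how a phenyl ring carrying an amine or a methoxy group would behave at this position remains open.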